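Amine Variation on a Sulfonyl Sulfur in MIA PaCa-2 Cells

A few compounds are considered here, and "the series" means these few. Any claim that something is new, unique, unknown or untested is made for them only; others in the source may bear on it.

Measured compounds:
Compound 1 `CCCN(CCC)S(=O)(=O)c1ccc(S(=O)(=O)N2CCC[C@@H](C(=O)OCC)C2)cc1`: 2300 nM
Compound 2 `CCOC(=O)[C@@H]1CCCN(S(=O)(=O)c2ccc(S(=O)(=O)N3CCOCC3)cc2)C1`: 23500 nM
Compound 3 `CCOC(=O)[C@@H]1CCCN(S(=O)(=O)c2ccc(S(=O)(=O)N(C)C)cc2)C1`: 900 nM

In a functional assay on MIA PaCa-2 cells (Homo sapiens) for inhibition, read by MTT assay, with a stated time of 7 days (a higher number here means a weaker inhibitor, a lower number a stronger inhibitor), compound 3 gives the lowest number of the three, separated from compound 1 by a 2.6-fold lower number from compound 1 to compound 3 (0.41 log units; beyond the scatter) and from compound 2 by a 26-fold lower number from compound 2 to compound 3 (1.42 log units; beyond the scatter). Compound 4 `CCOC(=O)[C@@H]1CCCN(S(=O)(=O)c2ccc(S(=O)(=O)N(CC)C(C)C)cc2)C1` differs from compound 3 by ethyl(isopropyl)amino in place of dimethylamino on a sulfonyl sulfur. Among the measured compounds shown here, the steps that bear on it both change the amine on the same sulfonyl sulfur: a 2.6-fold lower number from compound 1 to compound 3 (0.41 log units; beyond the scatter) and a 10-fold higher number from compound 1 to compound 2 (1.01 log units; beyond the scatter). Ethyl(isopropyl)amino stands between dimethylamino and dipropylamino in chain length, so a modest step upward in this assay is expected, about a 1.7-fold higher number from compound 3 to compound 4 (0.22 log units; within the scatter). Compound 4 is therefore estimated at 1500 nM, within 500 nM to 5000 nM.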

Compound 4, half-maximal inhibitory concentration: 1000 nM
Compound 4: the middle estimate sits 1.5-fold (0.18 log units) above what was measured, and the stated range covers the measured number.
By their numbers in this assay, from the lowest: compounds 3 and 4 (each within the scatter of the next); then compound 1; then compound 2.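

In this assay, ethyl(isopropyl)amino and dimethylamino cannot be told apart (a 1.1-fold higher number from compound 3 to compound 4 (0.05 log units; within the scatter)), so the larger group on this sulfonyl sulfur does not by itself separate compound 4 from compound 3. Compound 4 still stands clear of the dipropylamino compound (a 2.3-fold lower number from compound 1 to compound 4 (0.36 log units; beyond the scatter)) and further from the morpholin-4-yl compound (a 24-fold lower number from compound 2 to compound 4 (1.37 log units; beyond the scatter)), so heavy-atom count alone does not order these amines. Nothing available explains these steps.

From the compounds shown here alone, whether piperidin-1-yl, a ring amine without the morpholine oxygen, would read like compound 2 or compound 3 stays open, as does the reading for dibutylamino, a longer chain.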